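A few compounds are considered here, and "the series" means these few. Any claim that something is new, unique, unknown or untested is made for them only; others in the source may bear on it.

Compound 1, `O=c1cc(-c2ccccc2Cl)oc2ccc(OCCCCCCN3CCC(O)CC3)cc12`: in an assay on isolated protein (Cavia porcellus) with Sigma non-opioid intracellular receptor 1 (Homo sapiens) as the target, read by radioligand binding (a lower number here means a stronger inhibitor, a higher number a weaker inhibitor), compound 1 gives 29 nM.
Compound 2, `COc1cccc(-c2cc(=O)c3cc(OCCCCCCN4CCC(O)CC4)ccc3o2)c1`: in this assay compound 2 gives 111 nM.
Compound 3, `COc1ccc(-c2cc(=O)c3cc(OCCCCCCN4CCC(O)CC4)ccc3o2)cc1`: in this assay compound 3 gives 332 nM.

Compound 3 stands at the highest number of the three, its nearest neighbour being compound 2, with a step of a 3.0-fold higher number from compound 2 to compound 3 (0.48 log units; beyond the scatter), and the furthest compound 1, with a step of an 11-fold higher number from compound 1 to compound 3 (1.06 log units; beyond the scatter). The three measured compounds share one core and differ only in the aryl group on the core, and every measured step, including a 3.8-fold higher number from compound 1 to compound 2 (0.58 log units; beyond the scatter), is an exchange of one substituted phenyl for another.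

Compound 4, `O=c1cc(-c2ccncc2)oc2ccc(OCCCCCCN3CCC(O)CC3)cc12`, has not been measured in this assay. It departs from compound 3 by pyridin-4-yl in place of 4-methoxyphenyl on an aromatic carbon. Within the data shown here, none of the measured steps replaces the phenyl ring itself by another ring, so none of them bears directly on this change; they only show that this position of the core is sensitive to small changes, with steps ranging from modest to large, all raising the number from compound 1. Given that sensitivity and the absence of a direct precedent, compound 4 is expected to give a number somewhat higher than compound 3, a step of a 1.8-fold higher number from compound 3 to compound 4 (0.26 log units; within the scatter), but with a wide range. Compound 4 is therefore estimated at 600 nM, between 150 nM and 3000 nM.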

Compound 4, half-maximal inhibitory concentration: 308 nM
Estimate against measurement, compound 4: 1.9-fold (0.29 log units) above, and the stated range covers the measured number.
By their numbers in this assay, from the lowest: compound 1; then compound 2; then compounds 4 and 3 (each within the scatter of the next).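

In this assay, among these compounds, this is the first exchange of the phenyl ring itself for another ring, and the step for pyridin-4-yl in place of 4-methoxyphenyl is a 1.1-fold lower number from compound 3 to compound 4 (0.03 log units; within the scatter), so a ring with a hetero atom and no methoxy group on this aromatic carbon cannot be told apart from compound 3. Compound 4 also keeps the distance that already set compound 3 apart from the other two, with a 2.8-fold higher number from compound 2 to compound 4 (0.44 log units; beyond the scatter) and an 11-fold higher number from compound 1 to compound 4 (1.03 log units; beyond the scatter), which leaves the 2-chlorophenyl of compound 1 with the lowest number of the four, while the change of ring alone does not bring the number down toward it. No measurement beyond these numbers is at hand to explain the result.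

The step swaps the ring and removes the methoxy group at once, so the compounds shown leave open what an unsubstituted phenyl, a pyridin-3-yl or a pyridin-2-yl would give. Also open, on these data alone, is whether a chlorine on the pyridin-4-yl ring would move the number toward that of compound 1 at 29 nM.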